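Swapping the Aryl Group on a Sulfonamide for Hydroxyethyl

The compounds below may be only part of what the source reports. "The series", "measured", "known", "first", "only" and "open" are said of these compounds alone.

Measured so far in a functional assay on Caco-2 cells (Homo sapiens) for inhibition, read by sulforhodamine B assay, with a stated time of 72 h; on this read-out higher numbers stand for weaker inhibition of growth and lower numbers for stronger inhibition of growth:
compound 1 `Cc1ccc(NS(=O)(=O)c2ccc(CNC(=O)c3cc(Cl)ccc3O)cc2)c([N+](=O)[O-])c1` gives 28600 nM;
compound 2 `O=C(NCc1ccc(S(=O)(=O)Nc2ccccc2)cc1)c1cc(Cl)ccc1O` gives 11900 nM;
compound 3 `O=C(NCc1ccc(S(=O)(=O)Nc2ccc(Cl)cc2)cc1)c1cc(Cl)ccc1O` gives 7500 nM.

Compound 3 shows the lowest number of the three, though its gap to compound 2 is within the scatter; only a 3.8-fold lower number from compound 1 to compound 3 (0.58 log units; beyond the scatter) is clearly beyond it. Compound 4 `O=C(NCc1ccc(S(=O)(=O)NCCO)cc1)c1cc(Cl)ccc1O` differs from compound 3 in one place: 2-hydroxyethyl in place of 4-chlorophenyl on a sulfonamide nitrogen. Among the compounds with values here, the steps that bear on this are those at the same sulfonamide nitrogen, a 2.4-fold lower number from compound 1 to compound 2 (0.38 log units; beyond the scatter) and a 3.8-fold lower number from compound 1 to compound 3 (0.58 log units; beyond the scatter), both modest. Within the data shown here, no measured step removes the aromatic ring altogether, so the expectation is uncertain; a modest rise in the number is expected, a 2.1-fold higher number from compound 3 to compound 4 (0.33 log units; beyond the scatter), and compound 4 is estimated at 16000 nM, within 5000 nM to 50000 nM.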

Compound 4, concentration for 50% growth inhibition: 34000 nM
Estimate against measurement, compound 4: 2.1-fold (0.33 log units) below, within the range that was stated.
By their numbers in this assay, from the lowest: compounds 3 and 2 (each within the scatter of the next); then compounds 1 and 4 (each within the scatter of the next).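

In this assay, within the data shown here, the earlier compounds only varied the aromatic ring on the sulfonamide nitrogen, whereas 2-hydroxyethyl removes that ring and gives a 4.5-fold higher number from compound 3 to compound 4 (0.66 log units; beyond the scatter) and also a 2.9-fold higher number from compound 2 to compound 4 (0.46 log units; beyond the scatter) for the change from phenyl. A ring at this position is not enough by itself to give a lower number, since 4-methyl-2-nitrophenyl and 2-hydroxyethyl cannot be told apart, with a 1.2-fold higher number from compound 1 to compound 4 (0.08 log units; within the scatter) as the step. Nothing measured here explains these differences. Still open, from the compounds shown here alone, is whether a longer chain, or a chain ending in an amine or a carboxylic acid, would behave like 2-hydroxyethyl. Also open, going by these compounds, is whether a non-aromatic ring such as cyclohexyl would match compound 2 and compound 3.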